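A few compounds are considered here, and "the series" means these few. Any claim that something is new, unique, unknown or untested is made for them only; others in the source may bear on it.

In a functional assay on the whole organism for antagonist activity, with Rattus norvegicus as the target (on this read-out higher numbers stand for an effect only at larger amounts of compound and lower numbers for an effect already at smaller amounts), compound 3 `c1ccc2c(c1)CC2CCCN1CCN(c2cccc3c2OCCO3)CC1` gives 0.16 mg/kg, the lowest of the three numbers; the nearest is compound 1 `c1ccc2c(c1)CC(CCCN1CCN(c3cccc4c3OCCO4)CC1)C2`, which gives 0.63 mg/kg, and compound 2 `Clc1cccc2c1CC2CCCN1CCN(c2cccc3c2OCCO3)CC1` gives 0.63 mg/kg. Compound 4 `C1=C(CCN2CCN(c3cccc4c3OCCO4)CC2)c2ccccc2C1` differs from compound 3 by a group of 9 heavy atoms (9 carbon; one five-membered non-aromatic ring of carbon only, one six-membered aromatic ring of carbon only) in place of a group of 9 heavy atoms (9 carbon; one four-membered non-aromatic ring of carbon only, one six-membered aromatic ring of carbon only), on a saturated chain carbon, two bonds along the chain from an amine nitrogen in a ring. The measured step that bears on this is a 3.9-fold lower number from compound 1 to compound 3 (0.60 log units; beyond the scatter), in which a five-membered non-aromatic ring of carbon only gave way to a four-membered one. The change to compound 4 largely runs the other way, though the entering group sits two bonds along the chain from an amine nitrogen in a ring rather than three and has one double bond outside aromatic rings. The step of a 3.9-fold lower number from compound 2 to compound 3 (0.60 log units; beyond the scatter) concerns only chloro. A modest rise is therefore expected, a 3.1-fold higher number from compound 3 to compound 4 (0.49 log units; beyond the scatter). Compound 4 is estimated at 0.5 mg/kg, between 0.16 mg/kg and 1.6 mg/kg.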

Compound 4, minimum effective dose: 0.63 mg/kg
Compound 4: middle estimate off by 1.3-fold (0.10 log units), on the low side; the range from low to high includes it.
By their numbers in this assay, from the lowest: compound 3; then compounds 1, 2 and 4 (each within the scatter of the next).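

The change to compound 4 gives a 3.9-fold higher number from compound 3 to compound 4 (0.60 log units; beyond the scatter), so a second group with a five-membered non-aromatic ring, this one with 1 double bond outside aromatic rings, also leaves compound 3 with the lowest number. The step alters ring size and the double bond together, so it cannot show which of them matters. No available evidence explains the shift. Still open, going by these compounds, is how a six-membered non-aromatic ring of carbon only would behave in this place, and whether a methoxy group on the aromatic ring of compound 3 would keep its low number.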